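The source may report more compounds than this note shows. Statements on the series, on what has been measured and on what is new or still open speak of the compounds shown alone.

Compound 1 `Nc1scc(CN2CCN(C3CCCCC3)CC2)c1C(=O)c1ccc(Cl)cc1` is a small set's reference point. In an assay on CHO cells for displacement of a labelled ligand from adenosine receptor A1 (Homo sapiens) (a lower number here means tighter binding, a higher number weaker binding), compound 1 gives 1.1 nM, the highest of the two numbers shown, while compound 2 `Cc1ccc(N2CCN(Cc3csc(N)c3C(=O)c3ccc(Cl)cc3)CC2)cc1` gives 1 nM. The step of a 1.1-fold lower number from compound 1 to compound 2 (0.04 log units; within the scatter), the only measured one, swaps the same amine position. Compound 3 `N#Cc1ccc(N2CCN(Cc3csc(N)c3C(=O)c3ccc(Cl)cc3)CC2)cc1` changes compound 1 by 4-cyanophenyl in place of cyclohexyl on an amine nitrogen in a ring. Since the related move to compound 2 left the number essentially unchanged, a comparably small step is expected, a 1.2-fold higher number from compound 1 to compound 3 (0.07 log units; within the scatter), with no clear direction. Compound 3 is therefore estimated at 1.3 nM, likely between 0.4 nM and 4 nM.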

Compound 3, dissociation constant: 1.1 nM
Compound 3: the middle estimate sits 1.2-fold (0.07 log units) above what was measured; measured number inside the range.
By their numbers in this assay, from the lowest: compounds 2, 1 and 3 (each within the scatter of the next).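

In this assay, the amine nitrogen carries a non-aromatic cyclohexyl or an aromatic 4-cyanophenyl with the numbers within the scatter of each other, showing no change at the digits printed from compound 1 to compound 3 (within the scatter). On the aromatic ring itself, the two groups compared also sit within the scatter, with a 1.1-fold higher number from compound 2 to compound 3 (0.04 log units; within the scatter). No measurement shown explains why these groups read alike. Still open, going by these compounds, is whether the number stays this flat with a very different group on that nitrogen, such as a carboxylic acid, a longer carbon chain or a plain hydrogen.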